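A few compounds are considered here, and "the series" means these few. Any claim that something is new, unique, unknown or untested is made for them only; others in the source may bear on it.

Compound 1, `O=S(=O)(NN1C(=S)S/C(=C\c2ccc(Cl)c(Cl)c2)C1O)c1ccc(Cl)cc1`, compound 2, `O=C1/C(=C/c2ccc(Cl)c(F)c2)SC(=S)N1NS(=O)(=O)c1ccccc1`, and compound 3, `O=C1/C(=C/c2ccc(Cl)c(Cl)c2)SC(=S)N1NS(=O)(=O)c1ccccc1`, were each tested in a functional assay on ECV-304 cells (Homo sapiens) for cytotoxicity; a lower number here means a stronger inhibitor, a higher number a weaker inhibitor. Compound 1 gives > 50000 nM, which is a limit of the assay and not a number. In this assay compound 2 likewise gives > 50000 nM, a limit. Compound 3 gives > 50000 nM, again a limit. The step that the two limits leave unreadable from compound 3 to compound 2 therefore cannot be read, its change being (fluoro in place of chloro on an aromatic carbon). How the core of compound 1 differs from that of compound 3 is not broken down here. Compound 4, `O=S(=O)(NN1C(=S)S/C(=C\c2ccc(Cl)c(Cl)c2)C1O)c1ccc(F)cc1`, has not yet been measured in this assay; it differs from compound 1 by fluoro in place of chloro on an aromatic carbon, which is the same kind of change as that from compound 3 to compound 2, though here the place is para to a large group rather than ortho to a chloro group and meta to a large group. Because the limit of > 50000 nM in this assay, at which 3 of the 3 values shown sit, holds all three values, compound 1 is expected to give a step that the limit leaves unreadable from compound 1 to compound 4 to compound 4. Compound 4 is thus estimated at roughly 80000 nM, between 30000 nM and 300000 nM.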

Compound 4, half-maximal inhibitory concentration: > 50000 nM
Compound 4 gave a limit, no number; the forecaster's own chance of this, stated with the estimate: 85%; the middle value is on the limit's open side.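

In this assay compound 4 gives > 50000 nM, which is a limit and not a number. Compound 1 also stands at a limit, so no step between compound 1 and compound 4 can be read: the limit of > 50000 nM in this assay, at which 4 of the 4 values shown sit.

The compounds shown leave open how large any effect of fluoro in place of chloro is in this assay, and whether it has any effect at all.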